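A few compounds are considered here, and "the series" means these few. Any claim that something is new, unique, unknown or untested is made for them only; others in the source may bear on it.

Measured in a physicochemical assay for lipophilicity, measured as octanol-water partition; a lower number here means a more polar compound, a higher number a more lipophilic compound:
compound 1 `CC1=C(C(=O)OCc2cccnc2)C(c2ccc(C#N)cc2)C2=C(CCCC2=O)N1` gives 1.36
compound 2 `CC1=C(C(=O)OCc2ccccn2)C(c2ccco2)C2=C(CCCC2=O)N1` gives 1.4
compound 3 `CC1=C(C(=O)OCc2ccccn2)C(c2ccc(O)cc2)C2=C(CCCC2=O)N1` gives 1.58

Compound 1 lies within the scatter of both compound 2 and compound 3, so the three cannot be ranked. Compound 4 `CCCC1C(C(=O)OCc2cccnc2)=C(C)NC2=C1C(=O)CCC2` carries propyl in place of 4-cyanophenyl on a saturated ring carbon. Within the data shown here, the only measured step at this place is small (a number 0.18 log units higher from compound 2 to compound 3 (within the scatter)), and it involves neither propyl nor 4-cyanophenyl, so it offers limited guidance. No step beyond the scatter is expected in this assay, and the estimated step is correspondingly small (a number 0.09 log units higher from compound 1 to compound 4 (within the scatter)). Compound 4 is expected at 1.45 (estimated range 1 to 1.9).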

Compound 4, partition coefficient: 2.23
Estimate against measurement, compound 4: 0.78 log units below, and the stated range ends below it.
By their numbers in this assay, from the lowest: compounds 1, 2 and 3 (each within the scatter of the next); then compound 4.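

In this assay, among these compounds, propyl in place of 4-cyanophenyl on the saturated ring carbon gives a number 0.87 log units higher from compound 1 to compound 4 (beyond the scatter), the first step at this place beyond the scatter. The earlier step, a number 0.18 log units higher from compound 2 to compound 3 (within the scatter), joined two ring substituents, so the position can respond to its group when a ring gives way to an open chain, on this single pair. The change removes the aromatic ring and the nitrile together, and no available evidence bears on the cause of the step.

From the compounds shown here alone, it remains open which of the two losses carries the step, and unsubstituted phenyl at this place would separate them. Going by these compounds, whether a longer chain such as pentyl, or a chain ending in an amine, extends or reverses the step is also open.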